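Triazole-linked aryl swap and liver-cell cytotoxicity

The compounds below may be only part of what the source reports. "The series", "measured", "known", "first", "only" and "open" are said of these compounds alone.

Measured so far:
compound 1, `O=c1ccoc2cc(OCc3cn(Cc4ccc(Cl)cc4Cl)nn3)ccc12`: 13300 nM
compound 2, `O=c1ccoc2cc(OCc3cn(Cc4cccc(Cl)c4)nn3)ccc12`: 28400 nM

In a functional assay on QGY7701 cells (Homo sapiens) for cytotoxicity, read by MTT assay, with a stated time of 48 h (a higher number here means a weaker inhibitor, a lower number a stronger inhibitor), compound 1 gives 13300 nM and compound 2 gives 28400 nM. Going by the values given here, compound 2 thus stands highest of the two numbers, set apart from compound 1 by the only measured step, a 2.1-fold higher number from compound 1 to compound 2 (0.33 log units; beyond the scatter), which is modest. Compound 3, `O=c1ccoc2cc(OCc3cn(Cc4ccc([N+](=O)[O-])cc4)nn3)ccc12`, differs from compound 2 by 4-nitrophenyl in place of 3-chlorophenyl on a saturated chain carbon bound to an aromatic nitrogen. Among the compounds with values here, no measured step exchanges a chlorine-bearing ring for a nitro-bearing one, so the single step gives only a sense of scale. The expected change is a 1.1-fold higher number from compound 2 to compound 3 (0.02 log units; within the scatter), not clearly beyond the scatter. Compound 3 is therefore estimated at 30000 nM, between 10000 nM and 90000 nM.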

Compound 3, half-maximal inhibitory concentration: > 100000 nM
Compound 3 gave a limit, no number (the forecaster's own chance of this, stated with the estimate: 15%); middle value at least 3.3-fold (0.52 log units) away from the limit.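

At the saturated chain carbon bound to an aromatic nitrogen, the ring swap now moves the reading further than the chlorine change alone did: 4-nitrophenyl brings an at least 3.5-fold higher number from compound 2 to compound 3 (0.54 log units; beyond the scatter), and an at least 7.5-fold higher number from compound 1 to compound 3 (0.87 log units; beyond the scatter). The reading of compound 3 is a limit and not a number: the limit of > 100000 nM in this assay, at which 1 of the 3 values shown sits.

As far as these compounds go, how far compound 3 lies past that limit stays open, as does whether the shift belongs to the nitro group itself or to its place on the ring. Also open, from the compounds shown here alone, is how an amine or a carboxylic acid on this ring would read.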